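The source may report more compounds than this note shows. Statements on the series, on what has been measured and on what is new or still open speak of the compounds shown alone.

Measured so far:
compound 1, `Cc1csc2cc([C@H](C)Nc3ncnc(N)c3C#N)c(-c3cccc(CN4CCC(CN(C)Cc5ccccn5)CC4)c3)c(=O)n12`: 7
compound 2, `Cc1csc2cc([C@H](C)Nc3ncnc(N)c3C#N)c(-c3cccc(CN(C)CCCCN(C)Cc4ccccc4)c3)c(=O)n12`: 7

In a physicochemical assay for acid dissociation, compound 1 gives 7 and compound 2 gives 7; the two stand level at the digits shown, the gap lying within the scatter. For the measured compounds named here, the shared core is kept across the pair, and the two differ only in the side chain carried on the phenyl ring, with no single-point step between them to read.

The next compound, compound 3, `Cc1csc2cc([C@H](C)Nc3ncnc(N)c3C#N)c(-c3cccc(CN(C)CCCCN4C[C@@H](C)O[C@@H](C)C4)c3)c(=O)n12`, is not yet measured in this assay. It differs from compound 2 in one place: 2,6-dimethylmorpholin-4-yl in place of benzyl(methyl)amino on a saturated chain carbon, four bonds along the chain from an amine nitrogen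

Going by the values given here, with only two measured compounds, both level with each other, there is no step on which to base a direction. The expected step of no change at the digits printed from compound 2 to compound 3 (within the scatter) is none beyond the scatter. Compound 3 is therefore estimated at 7, with a range of 6.4 to 7.6.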

Compound 3, acid dissociation constant: 6.3
The estimate for compound 3 lay 0.70 log units above the measured number; the measured number lies below the stated range.
By their numbers in this assay, from the lowest: compound 3; then compounds 1 and 2 (each within the scatter of the next).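

In this assay, putting 2,6-dimethylmorpholin-4-yl in place of benzyl(methyl)amino on a saturated chain carbon, four bonds along the chain from an amine nitrogen, gives a number 0.70 log units lower from compound 2 to compound 3 (beyond the scatter); this is the only single-place step shown, and it establishes that the read-out responds to a change at this position, which the level pair of compound 1 and compound 2 could not show. The change replaces a six-membered aromatic ring of carbon only with a six-membered non-aromatic ring with 2 hetero atoms and adds 2 defined stereocentres, and this one step cannot separate these differences. No supporting measurement bears on why the number moved.

Still open, going by these compounds, is which part of the change carries the step; plain morpholin-4-yl or piperidin-1-yl at the same place could separate the ring oxygen from the methyl groups. On these data alone, whether the step persists on a shorter chain also remains open.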